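A few compounds are considered here, and "the series" means these few. Any claim that something is new, unique, unknown or untested is made for them only; others in the source may bear on it.

In a functional assay on HCT-116 cells (Homo sapiens) for cytotoxicity, read by MTT assay, with a stated time of 48 h (a lower number here means a stronger inhibitor, a higher number a weaker inhibitor), compound 1 `CNC(=O)c1cc(Oc2cccc(NC(=S)Nc3ccc(Cl)cc3)c2)ccn1` gives 39400 nM and compound 2 `CCNC(=O)c1cc(Oc2cccc(NC(=S)Nc3ccc(F)c(F)c3)c2)ccn1` gives 30300 nM. Compound 3 `CCNC(=O)c1cc(Oc2cccc(NC(=S)Nc3cccc(C(F)(F)F)c3)c2)ccn1` gives 19400 nM in this assay, the lowest of the three numbers, with compound 2 inside the scatter of it and compound 1 beyond it. Among the measured compounds shown here, the only measured single step, a 1.6-fold lower number from compound 2 to compound 3 (0.19 log units; within the scatter), sits on the thiourea side of the shared core. For the measured compounds named here, compound 4 `O=C(c1cc(Oc2cccc(NC(=S)Nc3cccc(C(F)(F)F)c3)c2)ccn1)N1CCCC1` instead carries pyrrolidin-1-yl in place of ethylamino on a carbonyl carbon, a place no measured step touches. With the three numbers spread so narrowly and nothing measured at the carbonyl, the step to compound 4 is expected to stay within the scatter, a 1.3-fold higher number from compound 3 to compound 4 (0.11 log units; within the scatter). Compound 4 is therefore estimated at 25000 nM in this assay, with a range of 8000 nM to 80000 nM.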

Compound 4, half-maximal inhibitory concentration: 19200 nM
Estimate against measurement, compound 4: 1.3-fold (0.11 log units) above, within the range that was stated.
By their numbers in this assay, from the lowest: compounds 4, 3, 2 and 1 (each within the scatter of the next, the first and the last beyond it).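

In this assay, among the compounds shown here, pyrrolidin-1-yl in place of ethylamino on a carbonyl carbon gives a 1.0-fold lower number from compound 3 to compound 4 (0.00 log units; within the scatter) and so provides the first reading at this position. The change removes the hydrogen-bond donor of ethylamino and adds a five-membered non-aromatic ring, yet the step stays within the scatter. No measurement shown here accounts for this result. From the compounds shown here alone, whether piperidin-1-yl, morpholin-4-yl or a longer chain on the carbonyl carbon would also stay within the scatter remains open. So does whether the same change would read alike with other groups on the thiourea side.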